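The source may report more compounds than this note shows. Statements on the series, on what has been measured and on what is new or still open speak of the compounds shown alone.

The study concerns three compounds built on one shared core. Compound 1 `COc1cc(OC)c2c(=O)cc(-c3ccc(OCCF)cc3)oc2c1` was tested in a functional assay (Homo sapiens) for antiproliferative activity, read by resazurin assay, with a stated time of 48 h, tested at 5 uM (a higher number here means a stronger effect of the compound at the concentration tested, a lower number a weaker effect), and was reported for compound 1 only as "not active" (no number reported), with no number given. Compound 2 `COc1cc(OC)c2c(=O)cc(-c3ccc(OCC(O)CN4CCCC4)cc3)oc2c1` gives in this assay a value of 21%. Among the compounds shown, compound 2 therefore carries the only number, and the one other entry stands without a figure, so no step between measured compounds can be drawn from these data.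

Compound 3 `COc1cc(OC)c2c(=O)cc(-c3ccc(OCC(O)CO)cc3)oc2c1` has not yet been measured. It differs from compound 2 by one change (hydroxy in place of pyrrolidin-1-yl on a saturated chain carbon, two bonds along the chain from an oxygen on a saturated carbon). Whether the pyrrolidin-1-yl group, or the hydroxy that replaces it, matters for the effect in this assay cannot be read from compound 1 or compound 2, since neither of them carries this variation alongside a comparable partner. Compound 3 is expected to give in this assay a value of 12%, within a range from 0% to 30%. The estimated step of a number 9 percentage points lower from compound 2 to compound 3 (within the scatter) is expected to be small, downward if anything, and probably not beyond the scatter of the assay.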

Compound 3, a percentage reported as inhibition, at one concentration (the size of the read-out at that concentration, not a potency): "not active" (no number reported)
Compound 3: no number reported, and the estimate cannot be compared.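

Within the data shown here, compound 3 carries no number in this assay, so no step from compound 2 to compound 3 can be read. The compounds shown leave open how much the change from pyrrolidin-1-yl to hydroxy alters the effect, if at all. Nothing shown here offers an explanation for this result.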